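Hydroxyalkyl groups on the shared core: estimate for compound 4

The source may report more compounds than this note shows. Statements on the series, on what has been measured and on what is new or still open speak of the compounds shown alone.

compound 1 `CCC(O)(c1cn(Cc2ccc3c(-c4ccccc4)c(CO)sc3c2)nn1)C(F)(F)F`: 19 nM
compound 2 `CCC(O)(c1cn(Cc2ccc3c(-c4ccccc4)csc3c2)nn1)C(F)(F)F`: 40 nM
compound 3 `CC[C@](O)(c1cn(Cc2ccc3c(-c4ccc(F)cc4)c(C(=O)O)sc3c2)nn1)C(F)(F)F`: > 10000 nM, a limit of the assay

In an assay on isolated protein for inhibition of Polyunsaturated fatty acid 5-lipoxygenase (Homo sapiens) (on this read-out higher numbers stand for weaker inhibition and lower numbers for stronger inhibition), compound 1 gives 19 nM and compound 2 gives 40 nM. For compound 3 the reading > 10000 nM is a limit of the assay (the limit of > 10000 nM in this assay, at which 1 of the 3 values shown sits), not a number. Among the two numbers compound 2 stands highest; its nearest neighbour is compound 1, below it beyond the scatter. For the measured compounds named here, the only measured step, a 2.1-fold higher number from compound 1 to compound 2 (0.32 log units; beyond the scatter), is modest. Compound 4 `CCC(O)(c1cn(Cc2ccc3c(-c4ccccc4)c(C(C)O)sc3c2)nn1)C(F)(F)F` is the unmeasured member; it differs from compound 2 by 1-hydroxyethyl in place of hydrogen on an aromatic carbon. Compound 4 thus carries a hydroxyl-bearing group again where compound 1 has hydroxymethyl, so a step of about the same modest size toward a lower number is expected in this assay. For compound 4 the expected value is 20 nM, the expected range runs from 8 nM to 50 nM, and the expected step is a 2.0-fold lower number from compound 2 to compound 4 (0.30 log units; within the scatter).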

Compound 4, half-maximal inhibitory concentration: 88 nM
For compound 4 the middle estimate is 4.4-fold (0.64 log units) below the measured one, and the stated range ends below it.
By their numbers in this assay, from the lowest: compound 1; then compound 2; then compound 4. At a limit, above all of these: compound 3.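

At this position, next to the ring sulfur, a hydroxyl-bearing group does not by itself give a lower number in this assay: hydroxymethyl lies on the lower side of hydrogen, while 1-hydroxyethyl gives a 2.2-fold higher number from compound 2 to compound 4 (0.34 log units; beyond the scatter). A single methyl on the saturated chain carbon is enough to reverse the direction, with a 4.6-fold higher number from compound 1 to compound 4 (0.67 log units; beyond the scatter). The data shown offer no measured basis for explaining this reversal.

Open, as far as these compounds go, are how an aminomethyl group or a longer hydroxyalkyl chain would read here. Also open, from the compounds shown here alone, is whether the separate mirror-image forms of compound 4 read alike.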